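This account rests on a few compounds, and the source may have more. Where it says the series, first, only, none or still open, it means among the compounds named here.

Measured compounds:
Compound 1, `O=S(=O)(c1cccc(F)c1)c1cn(C2CCNC2)c2ncccc12`, gives 2.7 nM in an assay on HeLa cells for displacement of a labelled ligand from 5-hydroxytryptamine receptor 6 (Homo sapiens); on this read-out lower numbers stand for stronger inhibition and higher numbers for weaker inhibition.
Compound 2, `O=S(=O)(c1ccc(F)cc1)c1cn(C2CCNC2)c2ncccc12`, gives 8.5 nM.
Compound 3, `CN1CCC(n2cc(S(=O)(=O)c3ccc(F)cc3)c3cccnc32)C1`, gives 5 nM.

Compound 2 has the highest number of the three. Going by the values given here, its gap to compound 3, a 1.7-fold lower number from compound 2 to compound 3 (0.23 log units; within the scatter), lies within the scatter, while the only step that alters the group on the sulfonyl sulfur, a 3.1-fold higher number from compound 1 to compound 2 (0.50 log units; beyond the scatter), is modest but beyond it.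

Compound 4, `O=S(=O)(Cc1ccc(Cl)s1)c1cn(C2CCNC2)c2ncccc12`, differs from compound 2 in one place: (5-chlorothiophen-2-yl)methyl in place of 4-fluorophenyl on a sulfonyl sulfur. The step to compound 3 does not bear on this change. Because a 3.1-fold higher number from compound 1 to compound 2 (0.50 log units; beyond the scatter) already shifted the number with a small change at that place, this larger change is expected to shift it further, most likely upward, though the direction is uncertain. Compound 4 is expected to give about 18 nM, within 4 nM to 90 nM. That estimate means an expected step of a 2.1-fold higher number from compound 2 to compound 4 (0.33 log units; beyond the scatter).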

Compound 4, inhibition constant: 1 nM
The estimate for compound 4 lay 18-fold (1.26 log units) above the measured number; measured number outside the range, below it.
By their numbers in this assay, from the lowest: compound 4; then compounds 1, 3 and 2 (each within the scatter of the next, the first and the last beyond it).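

On the sulfonyl sulfur, (5-chlorothiophen-2-yl)methyl gives an 8.5-fold lower number from compound 2 to compound 4 (0.93 log units; beyond the scatter) and a 2.7-fold lower number from compound 1 to compound 4 (0.43 log units; beyond the scatter) in this assay. This position therefore takes a five-membered aromatic ring with a hetero atom, not only a fluorophenyl, and the number can fall here as well as rise. No evidence shown explains this fall.

As far as these compounds go, the group differs from the fluorophenyls in its ring, its chlorine and its carbon link at once, so the contribution of each stays open. Benzyl or unsubstituted thiophen-2-ylmethyl on the sulfonyl sulfur would help separate them.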